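Series notes: 4-chlorobenzyl on the hydroxy oxygen of compound 2

The source may report more compounds than this note shows. Statements on the series, on what has been measured and on what is new or still open speak of the compounds shown alone.

Three compounds of this series have numbers in an ADME assay on cells (Mus musculus, strain BALB/c) for cytotoxicity, read by MTT assay, with a stated time of 24 h; a lower number here means that less compound is tolerated, a higher number that more compound is tolerated. Compound 1 `COc1cc(-c2nnc(SCc3ccc([N+](=O)[O-])cc3)o2)ccc1O` gives 688000 nM; compound 2 `COc1cc(-c2nnc(SCc3ccc(Cl)cc3)o2)ccc1O` gives 480000 nM; compound 3 `COc1cc(-c2nnc(SCc3ccccc3Br)o2)ccc1O` gives 363000 nM. Compound 2 holds the second highest of the three numbers, with compound 3 nearest and compound 1 furthest, and both gaps fall within the scatter. The two measured steps are also small: a 1.4-fold lower number from compound 1 to compound 2 (0.16 log units; within the scatter) and a 1.3-fold lower number from compound 2 to compound 3 (0.12 log units; within the scatter). Both steps alter the group on the sulfur-bound chain carbon; neither touches the oxygen on the aromatic ring of the shared core.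

Compound 4 `COc1cc(-c2nnc(SCc3ccc(Cl)cc3)o2)ccc1OCc1ccc(Cl)cc1` differs from compound 2 at exactly that oxygen: 4-chlorobenzyl in place of hydrogen on an oxygen on an aromatic ring. Among the compounds with values here, no measured step in this assay bears on this position, so there is no direct precedent for the size or direction of the effect. What the series does show is that every change tried so far has stayed within the scatter, so the working expectation is a number near that of compound 2, with a lean toward a lower value given the larger substituent.

Compound 4 is expected to give 250000 nM, with a range of 90000 nM to 700000 nM. This estimate for compound 4 means an expected 1.9-fold lower number from compound 2 to compound 4 (0.28 log units; within the scatter).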

Compound 4, half-maximal cytotoxic concentration: 136000 nM
Compound 4: the middle estimate sits 1.8-fold (0.26 log units) above what was measured, within the range that was stated.
By their numbers in this assay, from the lowest: compound 4; then compounds 3, 2 and 1 (each within the scatter of the next).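

In this assay, within the data shown here, the change from hydroxy to (4-chlorobenzyl)oxy gives a 3.5-fold lower number from compound 2 to compound 4 (0.55 log units; beyond the scatter) and is the only step that lies beyond the scatter, which marks the oxygen on the aromatic ring as a position where the number can move, whereas the two changes on the sulfur-bound chain carbon stayed within the scatter. The direction at this position is toward less compound being tolerated, although this rests on a single pair and the size of the step is modest. That pair combines the loss of the hydroxy hydrogen with the arrival of the 4-chlorobenzyl group, so the two contributions cannot be separated, and nothing available explains the step.

Still open, as far as these compounds go, is whether the shift follows from any substituent on this oxygen or from 4-chlorobenzyl in particular, a question that benzyl without the chlorine, an ethyl group, a longer chain, or a chain ending in an amine or a carboxylic acid would address. Also open, from the compounds shown here alone, is whether the same change at this oxygen gives a step of similar size when the nitro or 2-bromophenyl variants of the sulfur-bound group are present.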